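The compounds below may be only part of what the source reports. "The series", "measured", "known", "first", "only" and "open" are said of these compounds alone.

Working notes on the series. The read-out throughout is a functional assay on MCF7 cells (Homo sapiens) for cytotoxicity, read by MTT assay, with a stated time of 24 h; on this read-out higher numbers stand for weaker inhibition and lower numbers for stronger inhibition. Of the compounds shown here, two have been measured. Compound 1 `O=C(CN1CCN(c2cccc(Cl)c2)CC1)N1CCN(c2nnc(-c3ccccc3)c(-c3ccccc3)n2)CC1` gives 56300 nM in this assay. Within the data shown here, compound 2 `Cc1ccc(-c2nnc(N3CCN(C(=O)CN4CCN(c5ccccc5)CC4)CC3)nc2-c2ccc(C)cc2)cc1` gives 914000 nM in this assay, the highest of the two numbers, and compound 1 sits well below it by more than the usual scatter; compounds 1 and 2 differ in more than one place, so the two values show only that compound 2 is the weaker of the pair, not which change carries the gap.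

The next compound, compound 3 `COc1cccc(N2CCN(CC(=O)N3CCN(c4nnc(-c5ccc(C)cc5)c(-c5ccc(C)cc5)n4)CC3)CC2)c1`, is compound 2 with one change: methoxy in place of hydrogen on an aromatic carbon. Among the measured compounds shown here, no measured pair in this set isolates that change, so there is no step of the kind to lean on. With nothing in the measured compounds speaking for a large effect either way, a step from compound 2 to compound 3 of a 1.5-fold lower number from compound 2 to compound 3 (0.18 log units; within the scatter) is expected, that is, a shift that may stay within the scatter or lean slightly toward a lower number. Compound 3 is accordingly estimated at 600000 nM in this assay, with a range from 150000 nM to 2000000 nM.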

Compound 3, half-maximal inhibitory concentration: 867000 nM
Beside the measured number, compound 3's estimate is 1.4-fold (0.16 log units) below it; the measured number falls inside the stated range.
By their numbers in this assay, from the lowest: compound 1; then compounds 3 and 2 (each within the scatter of the next).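

Methoxy in place of hydrogen on an aromatic carbon, meta to a large group, gives in this assay a 1.1-fold lower number from compound 2 to compound 3 (0.02 log units; within the scatter) and is the first change in the series that can be read alone, as compounds 1 and 2 differ in more than one place. Among these compounds, at this position on the core shared by compound 2 and compound 3, phenyl to 3-methoxyphenyl therefore leaves the cytotoxicity read-out unresolved from its starting point, and the added oxygen and carbon bring no measurable step here. Nothing else reported for these compounds bears on this result or accounts for it.

Among the compounds shown here, whether an amine, a carboxylic acid or a longer chain such as butoxy in this same place would give a step beyond the scatter remains open, since methoxy is the only group read here against hydrogen. Also open, as far as these compounds go, is whether methoxy in place of hydrogen would give a similar step on the core of compound 1, or at another carbon of the same six-membered aromatic ring.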